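The source may hold more compounds than are shown below. What is called first, only, known or untested is meant among the compounds shown, and "the series" means these compounds.

In a functional assay on MGC-803 cells (Homo sapiens) for inhibition, read by MTT assay, with a stated time of 72 h (a lower number here means a stronger inhibitor, a higher number a weaker inhibitor), compound 1 (`Cc1ccc(NC(=O)C2CCN(C/C=C/c3ccccc3)CC2)cc1`) gives 24100 nM, compound 3 (`O=C(Nc1cccc(C(F)(F)F)c1)C1CCN(C/C=C/c2ccccc2)CC1`) gives 9590 nM, and compound 2 (`CCCCc1ccc(NC(=O)C2CCN(C/C=C/c3ccccc3)CC2)cc1`) gives 2570 nM, the lowest number of the three. Compound 4 (`CN1CCN(c2ccc(NC(=O)C3CCN(C/C=C/c4ccccc4)CC3)cc2)CC1`) departs from compound 2 with 4-methylpiperazin-1-yl in place of butyl on an aromatic carbon, (4-methylpiperazin-1-yl in place of butyl on an aromatic carbon). Among the measured compounds shown here, the only measured step that bears on this change is a 9.4-fold lower number from compound 1 to compound 2 (0.97 log units; beyond the scatter), which came with propyl in place of hydrogen on a saturated chain carbon bound to an aromatic carbon. For the measured compounds named here, with the butyl gone, part of that step is expected to be given back, though no measured compound carries a ring at this place. The expected change is a 3.1-fold higher number from compound 2 to compound 4 (0.49 log units; beyond the scatter), a modest move to a higher number. For compound 4 the estimated value is 8000 nM, with an expected range of 2500 nM to 25000 nM.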

Compound 4, half-maximal inhibitory concentration: 14000 nM
Estimate against measurement, compound 4: 1.8-fold (0.24 log units) below; low and high end bracket the measured number.
By their numbers in this assay, from the lowest: compound 2; then compounds 3, 4 and 1 (each within the scatter of the next, the first and the last beyond it).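

With a 5.4-fold higher number from compound 2 to compound 4 (0.74 log units; beyond the scatter) in this assay the gain seen with butyl on this aromatic carbon is lost once 4-methylpiperazin-1-yl stands there. The step of a 1.7-fold lower number from compound 1 to compound 4 (0.24 log units; within the scatter) puts this ring on a par with methyl, so a larger group at this place does not by itself bring the lower number seen with butyl.

As far as these compounds go, whether a longer chain such as hexyl, or a morpholine ring, would side with butyl or with 4-methylpiperazin-1-yl remains open. Nothing measured here accounts for the gap between these two groups.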